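Swapping Chloro for Methyl on a Benzyl Ring

The compounds below may be only part of what the source reports. "The series", "measured", "known", "first", "only" and "open" are said of these compounds alone.

Of the compounds shown here, two have been measured in an assay on CHO cells for displacement of a labelled ligand from transient receptor potential cation channel subfamily V member 1 (Rattus norvegicus); on this read-out higher numbers stand for weaker inhibition and lower numbers for stronger inhibition. Compound 1 `CC(C)(C)c1ccc(CNC(=O)C2(c3ccc(NS(C)(=O)=O)cc3)CC2)cc1` gives 610 nM. Compound 2 `CC(C(=O)NCc1ccc(Cl)cc1)c1ccc(NS(C)(=O)=O)c(F)c1` gives 1060 nM, the higher of the two numbers, but its gap to compound 1 lies within the scatter, so the two cannot be told apart on these data.

Compound 3 `Cc1ccc(CNC(=O)C(C)c2ccc(NS(C)(=O)=O)c(F)c2)cc1` differs from compound 2 in one place: methyl in place of chloro on an aromatic carbon. Among the compounds with values here, no measured pair shows this exact change, so the expectation rests on the change alone: a single heavy atom replaced by another of the same size class, with no change in hydrogen-bond donors or acceptors. A small step is expected, if any, and not beyond the scatter. Compound 3 is therefore estimated to give 1500 nM, with a likely range from 500 nM to 4500 nM. The expected step from compound 2 to compound 3 is a 1.4-fold higher number from compound 2 to compound 3 (0.15 log units; within the scatter).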

Compound 3, inhibition constant: 3100 nM
Compound 3: middle estimate off by 2.1-fold (0.32 log units), on the low side; the range from low to high includes it.
By their numbers in this assay, from the lowest: compounds 1 and 2 (each within the scatter of the next); then compound 3.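

In this assay going from 4-chlorobenzyl to 4-methylbenzyl gives a 2.9-fold higher number from compound 2 to compound 3 (0.47 log units; beyond the scatter) and so shows that this position, para to a large group, responds to the swap of one heavy atom for another. The number changes even though neither group brings any hydrogen-bond donors or acceptors, so those counts alone do not predict the outcome here. Of these two groups on this core, chloro goes with the stronger inhibition, and no measurement on hand says why.

The compounds shown leave open how a bromo or a methoxy group would read at this same position. They also leave open whether chloro and methyl would differ in the same direction on the core of compound 1, which carries a different group at the matching place.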